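The compounds below may be only part of what the source reports. "The series", "measured", "known", "first", "only" and "open" are said of these compounds alone.

Working notes on the series, read on an ADME assay on microsomes from liver (Homo sapiens) for metabolic stability, with a stated time of 30 min (a higher number here means that more of the compound is left, a lower number that less of the compound is left), as the only measure at hand. Compound 1 (`CC(C)[C@@H](CO)n1cc(C(=O)O)c(=O)c2nc(Cc3cccc(Cl)c3F)ccc21`) carries the entry "not determined" (no result reported) in this assay and so adds no number. For the measured compounds named here, compound 2 (`CC(C)(C)[C@@H](CO)n1cc(C(=O)O)c(=O)c2cc(Cc3cccc(Cl)c3F)c(O)nc21`) gives 87% in this assay and is the only compound here with a number. Compound 3 (`COc1nc2c(cc1Nc1ccc(Cl)c(F)c1)c(=O)c(C(=O)O)cn2[C@H](CO)C(C)C`) carries the entry "not determined" (no result reported) in this assay and has no single number, as does one further compound, so its standing against compound 2 cannot be stated.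

The structural change leading to compound 4 (`COc1nc2c(cc1NCc1c(F)cc(F)cc1F)c(=O)c(C(=O)O)cn2[C@H](CO)C(C)C`) is 2,4,6-trifluorobenzyl in place of 4-chloro-3-fluorophenyl on a nitrogen on an aromatic ring and places 2,4,6-trifluorobenzyl in place of 4-chloro-3-fluorophenyl on a nitrogen on an aromatic ring. The same difference reads as (4-chloro-3-fluorophenyl)amino to (2,4,6-trifluorobenzyl)amino.

Going by the values given here, no step between measured compounds is available to size this change, and compound 3 offers no starting value. The working expectation in this assay is therefore no step beyond the usual scatter, in neither direction, and this is weakly supported. Among the compounds with values here, the only anchor is compound 2 at 87% in this assay, so the expected range is kept wide. Compound 4 is estimated at 78% in this assay (expected range 55% to 95%).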

Compound 4, percent of the compound remaining: 82%
For compound 4 the middle estimate is 4 percentage points below the measured one, and the stated range covers the measured number.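

In this assay, for the compounds shown here, compound 4 gives 82% while compound 3 has no single number, so no step from compound 3 to compound 4 can be read. The compounds shown leave open how 2,4,6-trifluorobenzyl in place of 4-chloro-3-fluorophenyl alters this read-out. No available evidence bears on the result for compound 4.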